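The compounds below may be only part of what the source reports. "The series", "measured", "known", "first", "only" and "open" are said of these compounds alone.

Of the compounds shown here, two have so far been measured in a functional assay on SK-MEL-5 cells (Homo sapiens) for inhibition, read by sulforhodamine B assay, with a stated time of 48 h; a lower number here means a stronger inhibitor of growth, a higher number a weaker inhibitor of growth. Compound 2, `Nc1cc(N)c2nc(-c3ccccc3)c(NCc3ccc(Cl)c(Cl)c3)nc2c1`, gives 3470 nM in this assay, while compound 1, `CCOC(=O)[C@H](CCC(=O)O)NC(=O)c1ccc(CNc2nc3cc(N)cc(N)c3nc2-c2ccccc2)cc1`, gives 69200 nM. Of these two numbers, compound 2 stands lower, and the gap between compound 2 and compound 1 lies well beyond the usual scatter of repeated measurements, so compound 2 is the stronger growth inhibitor of the pair. The two compounds differ in more than one place, so no single structural change can be tied to that gap.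

Compound 3, `COc1ccc(CNc2nc3cc(N)cc(N)c3nc2-c2ccccc2)cc1OC`, has not yet been measured. It differs from compound 2 in one place: 3,4-dimethoxyphenyl in place of 3,4-dichlorophenyl on a saturated chain carbon bound to a nitrogen on an aromatic ring. Within the data shown here, no measured pair shows this change on its own, so its effect cannot be read from the data at hand. With that uncertainty, a modest weakening of growth inhibition from compound 2 to compound 3 is expected, a 2.3-fold higher number from compound 2 to compound 3 (0.36 log units; beyond the scatter), though a result within the scatter would not be surprising. Compound 3 is therefore estimated to give 8000 nM in this assay, with a plausible range from 2000 nM to 30000 nM.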

Compound 3, concentration for 50% growth inhibition: 10000 nM
Estimate against measurement, compound 3: 1.3-fold (0.10 log units) below; the range from low to high includes it.
By their numbers in this assay, from the lowest: compound 2; then compound 3; then compound 1.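

In this assay, among these compounds, this is the first comparison that changes only one place, the group on a saturated chain carbon bound to a nitrogen on an aromatic ring. Putting 3,4-dimethoxyphenyl in place of 3,4-dichlorophenyl gives a 2.9-fold higher number from compound 2 to compound 3 (0.46 log units; beyond the scatter), so the group at this place does affect growth inhibition, even though the step is modest and the more active of the pair is the dichloro compound. The two groups share one six-membered aromatic ring of carbon only, but they differ in their atoms and in hydrogen-bond acceptors, 2 against 0, and nothing at hand shows which of these differences matters for the step.

Among the compounds shown here, with only two groups compared here, it remains open what a plain phenyl, a phenyl with a single chlorine, or a phenyl carrying an amine would give at this place. Going by these compounds, it also remains open whether the same exchange would produce a step of similar size if a methyl group replaced the phenyl on the shared core.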